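Chain extension beside the amide in two related series

A few compounds are considered here, and "the series" means these few. Any claim that something is new, unique, unknown or untested is made for them only; others in the source may bear on it.

Compound 1, `CCC(=O)NCc1ccc(OC)c(F)c1`, and compound 2, `CCCC(=O)NCc1ccc(OC)c(F)c1`, share a core and differ in one place. In an assay on isolated protein for agonist activity at melatonin receptor type 1C (Xenopus laevis), read by spectrophotometry (a higher number here means a larger maximal response, a lower number a smaller maximal response), compound 1 gives 51%, and compound 2 gives 57%. The change between them is methyl in place of hydrogen on a saturated chain carbon, two bonds along the chain from a carbonyl carbon, and it made a number 6 percentage points higher from compound 1 to compound 2 (within the scatter).

Compound 3, `CCC(=O)NCCCc1ccc(F)c(OC)c1`, is built on a different core; how its core differs from that of compound 1 is not broken down here. In this assay compound 3 gives 89%, which is the highest of the three numbers, and the steps from compound 1 and from compound 2 up to compound 3 both lie beyond the scatter.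

Compound 4, `CCCC(=O)NCCCc1ccc(F)c(OC)c1`, has not yet been measured. It differs from compound 3 by methyl in place of hydrogen on a saturated chain carbon, two bonds along the chain from a carbonyl carbon, the same change that separates compound 1 from compound 2, since both place descriptions read alike word for word.

Because that earlier change gave only a number 6 percentage points higher from compound 1 to compound 2 (within the scatter), the step from compound 3 to compound 4 is expected to be small as well, estimated at a number 4 percentage points higher from compound 3 to compound 4 (within the scatter). On this basis compound 4 is expected to reach about 93% in this assay, with a range estimated from 80% to 105%. Within the data shown here, this expectation rests on the single earlier pair alone, so it is held loosely.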

Compound 4, largest response reached (reported as efficacy), in percent of the reference or control that the assay uses: 89%
Beside the measured number, compound 4's estimate is 4 percentage points above it, and the stated range covers the measured number.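

In this assay, methyl in place of hydrogen on a saturated chain carbon, two bonds along the chain from a carbonyl carbon, gives no change at the digits printed from compound 3 to compound 4 (within the scatter). Set beside the earlier step on the core of compound 1, the change reads the same on both cores, with no difference that stands out from the ordinary spread of repeated measurements: the same change on two cores in this assay, a number 6 percentage points higher (within the scatter) from compound 1 to compound 2 and no change at the digits printed (within the scatter) from compound 3 to compound 4, 6 percentage points apart, within the scatter of two such steps. This shows that, for these two pairs, going from propanoyl to propylcarbonyl carried over from one core to the other as a step too small to read, but it does not show that the change has no effect at all, that a small effect is absent, or that the same would hold on any further core, and it speaks only to the largest response reached, not to any other measure of these compounds.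

The compounds shown leave open whether a longer chain, a branched chain such as isopropyl, or a cyclopropyl ring in that same place would also leave the response as it stands on both cores. They also leave open what an amine or a carboxylic acid in that place would do to the response on either core.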